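Swapping an amide for an oxadiazole on a piperidine core

The source may report more compounds than this note shows. Statements on the series, on what has been measured and on what is new or still open speak of the compounds shown alone.

Measured compounds:
- Compound 1 `CCN(CC)S(=O)(=O)c1ccc(S(=O)(=O)N2CCC[C@@H](C(=O)N(C)C(C)C)C2)cc1` gives > 10000 nM in a functional assay on MIA PaCa-2 cells (Homo sapiens) for inhibition, read by MTT assay, with a stated time of 3 days; on this read-out lower numbers stand for stronger inhibition and higher numbers for weaker inhibition; this is a limit of the assay.
- Compound 2 `CCN(CC)C(=O)[C@@H]1CCCN(S(=O)(=O)c2ccc(S(=O)(=O)N(CC)CC)cc2)C1` gives > 10000 nM in this assay; this is a limit.
- Compound 3 `CCN(CC)S(=O)(=O)c1ccc(S(=O)(=O)N2CCC[C@@H](C(=O)NC3COC3)C2)cc1` gives > 10000 nM in this assay; this is a limit.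

All three compounds share the same core and differ only in the amine on the carbonyl carbon. None of them reaches a readable number: compound 3 sits at the limit, as do the two others. The steps a step that the two limits leave unreadable from compound 1 to compound 2, a step that the two limits leave unreadable from compound 1 to compound 3 and a step that the two limits leave unreadable from compound 2 to compound 3 are therefore all unreadable in size due to the limit of > 10000 nM in this assay, at which 3 of the 3 values shown sit.

Compound 4 `CCN(CC)S(=O)(=O)c1ccc(S(=O)(=O)N2CCC[C@@H](c3nc(C)no3)C2)cc1` takes a different route: 3-methyl-1,2,4-oxadiazol-5-yl in place of (oxetan-3-yl)carbamoyl on a saturated ring carbon. For the measured compounds named here, no measured step bears directly on this change, since every step so far only swapped one amine for another and left the carbonyl in place. With the three measured compounds all at the limit, there is no sign that the shared core supports inhibition at all, and the step from compound 3 to compound 4 cannot be anchored to a measured change.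

Compound 4 is therefore expected to remain near the limit, at an estimated 15000 nM (range 5000 nM to 50000 nM), which would mean an expected step that the limit leaves unreadable from compound 3 to compound 4.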

Compound 4, half-maximal inhibitory concentration: > 10000 nM
Compound 4: only a limit was reported; the forecaster's own chance of this, stated with the estimate: 85%; the middle value does not contradict the limit.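

In this assay compound 4 gives > 10000 nM as a limit. For the compounds shown here, no step from compound 1, compound 2 or compound 3 to compound 4 can be read, due to this: the limit of > 10000 nM in this assay, at which 4 of the 4 values shown sit. The compounds shown leave open whether any group on the shared core gives readable inhibition.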